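This account rests on a few compounds, and the source may have more. Where it says the series, first, only, none or still open, it means among the compounds named here.

Of the compounds shown here, three sharing a core have been measured in a physicochemical assay for lipophilicity, measured as octanol-water partition (on this read-out higher numbers stand for higher lipophilicity and lower numbers for lower lipophilicity), and they differ in what sits on one saturated chain carbon. Compound 1 `CC(=O)N[C@H](C(=O)N1C[C@H](O)C[C@H]1C(=O)N[C@@H](CCC(=O)O)c1ccc(-c2scnc2C)cc1)C(C)(C)C`, with a carboxy group there, gives 1.02. Compound 2 `CCOC(=O)CC[C@H](NC(=O)[C@@H]1C[C@@H](O)CN1C(=O)[C@@H](NC(C)=O)C(C)(C)C)c1ccc(-c2scnc2C)cc1`, with ethyl on the oxygen of that group, gives 1.59. Compound 3 `CCCC[C@H](NC(=O)[C@@H]1C[C@@H](O)CN1C(=O)[C@@H](NC(C)=O)C(C)(C)C)c1ccc(-c2scnc2C)cc1` stands highest of the three at 2.75.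

Compound 4 `CC(=O)N[C@H](C(=O)N1C[C@H](O)C[C@H]1C(=O)N[C@@H](CCc1ccc(O)cc1)c1ccc(-c2scnc2C)cc1)C(C)(C)C` has 4-hydroxyphenyl in place of the ethyl of compound 3, on a saturated chain carbon, three bonds along the chain from an amide-type nitrogen and an aromatic carbon (4-hydroxyphenyl in place of ethyl on a saturated chain carbon, three bonds along the chain from an amide-type nitrogen and an aromatic carbon).

The steps of a number 1.73 log units higher from compound 1 to compound 3 (beyond the scatter) and a number 1.16 log units higher from compound 2 to compound 3 (beyond the scatter) were large and touch this same carbon, while a number 0.57 log units higher from compound 1 to compound 2 (beyond the scatter) was modest. They show that this assay responds to changes here, but none of them introduces a ring. The entering group adds both a carbon ring and a hydrogen-bond donor, and these measurements cannot show how the two weigh against each other. The expected step, a number 0.10 log units higher from compound 3 to compound 4 (within the scatter), is slightly upward and stays within the scatter. The estimate for compound 4 is 2.85, with an expected range of 2.35 to 3.35.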

Compound 4, partition coefficient: 3.08
Estimate against measurement, compound 4: 0.23 log units below; low and high end bracket the measured number.
By their numbers in this assay, from the lowest: compound 1; then compound 2; then compound 3; then compound 4.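

In this assay, for the compounds shown here, 4-hydroxyphenyl in place of ethyl gives a number 0.33 log units higher from compound 3 to compound 4 (beyond the scatter), so the only group here that carries a ring, which also brings a hydrogen-bond donor, takes this carbon to the highest number of the four compounds. The gaps to the other two groups are larger, with a number 1.49 log units higher from compound 2 to compound 4 (beyond the scatter) for ethoxycarbonyl and a number 2.06 log units higher from compound 1 to compound 4 (beyond the scatter) for carboxy, and the order at this carbon now runs carboxy, ethoxycarbonyl, ethyl, 4-hydroxyphenyl. No measurement shown accounts for this order.

The ring and the hydroxy group enter together, so the compounds shown leave open how much of the step belongs to each. A plain phenyl at this carbon would separate the two, and a 4-aminophenyl would show how another group at that spot on the ring compares.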